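The source may hold more compounds than are shown below. What is called first, only, known or untested is meant among the compounds shown, and "the series" means these compounds.

Compound 3 `O=C(CCc1ccc(C(F)(F)F)cc1)Nc1ccc2nc(N3CCC4(CCNC4)C3)ccc2c1` is one of three amides that share a common core and differ only in the group on that core. In a functional assay on HEK293 cells for activation of melanin-concentrating hormone receptor 1 (Rattus norvegicus), read by inositol phosphate accumulation (a lower number here means that less compound is needed, a higher number that more compound is needed for the effect), compound 3 gives 140 nM, the highest of the three numbers measured, yet it lies within the usual scatter of both other values. Compound 1 `CC(C)C(=O)NC1CCN(c2ccc3cc(NC(=O)CCc4ccc(C(F)(F)F)cc4)ccc3n2)C1` gives 90 nM, and compound 2 `CN(C)c1ccc2cc(NC(=O)CCc3ccc(C(F)(F)F)cc3)ccc2n1` gives 110 nM. The steps of a 1.6-fold higher number from compound 1 to compound 3 (0.19 log units; within the scatter) and a 1.3-fold higher number from compound 2 to compound 3 (0.10 log units; within the scatter) show that exchanging the group at this position has so far moved the number only within the scatter. Compound 4 `O=C(CCc1ccc(C(F)(F)F)cc1)Nc1ccc2nc(N3CC4CCC3C4)ccc2c1` differs from compound 3 in that (a group of 7 heavy atoms (6 carbon, 1 nitrogen; one five-membered non-aromatic ring of carbon only, one five-membered non-aromatic ring with 1 hetero atom) in place of a group of 9 heavy atoms (7 carbon, 2 nitrogen; 2 five-membered non-aromatic rings with 1 hetero atom each), on an aromatic carbon). Both earlier steps bear on this change: each replaced the same group with a different one, and both were small. The expected step of no change at the digits printed from compound 3 to compound 4 (within the scatter) is therefore no larger than the scatter, in either direction. Compound 4 is estimated at 140 nM, with a range from 60 nM to 350 nM.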

Compound 4, half-maximal effective concentration: 150 nM
For compound 4 the middle estimate is 1.1-fold (0.03 log units) below the measured one; low and high end bracket the measured number.
By their numbers in this assay, from the lowest: compounds 1, 2, 3 and 4 (each within the scatter of the next).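

In this assay, the group that enters has 0 hydrogen-bond donors where the group that leaves has 1, yet the step is only a 1.1-fold higher number from compound 3 to compound 4 (0.03 log units; within the scatter), so losing that donor has no visible effect on the number here. The comparisons with the other two groups, a 1.4-fold higher number from compound 2 to compound 4 (0.13 log units; within the scatter) and a 1.7-fold higher number from compound 1 to compound 4 (0.22 log units; within the scatter), are equally small, and all four groups, from dimethylamino to the largest, now cannot be told apart at this position. Nothing available explains why these exchanges change so little.

On these data alone, all four groups join the core through a nitrogen, so it remains open whether a methoxy group or a carboxylic acid at this place would also stay within the scatter. Also open, as far as these compounds go, is whether the picture would hold with a nitrile in place of the trifluoromethyl group.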